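Phenyl for Trifluoromethylphenoxy: Expected Lipophilicity of Compound 4

The source may hold more compounds than are shown below. What is called first, only, known or untested is meant among the compounds shown, and "the series" means these compounds.

Of the compounds shown here, three built on one shared core have been measured in a physicochemical assay for lipophilicity, read by HPLC, tested at 5 mM; on this read-out higher numbers stand for higher lipophilicity and lower numbers for lower lipophilicity. Compound 1 `CC(Oc1ccc(Oc2ccc(C(F)(F)F)cc2)cc1)C(=O)Cn1nnc(-c2ccc(Cl)cc2)n1` gives 7 in this assay. Compound 2 `CC(Oc1ccc(-c2ccccc2)cc1)C(=O)Cn1nnc(-c2ccc(Cl)cc2)n1` gives 6.1. Compound 3 `CC(Oc1ccc(Oc2ccc(C(F)(F)F)cc2)cc1)C(=O)Cn1nnc(-c2ccc(C(=O)O)cc2)n1` gives 3.5, the lowest of the three. Compound 4 `CC(Oc1ccc(-c2ccccc2)cc1)C(=O)Cn1nnc(-c2ccc(C(=O)O)cc2)n1` has not been measured yet.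

Compound 2 differs from compound 1 by phenyl in place of 4-(trifluoromethyl)phenoxy on an aromatic carbon, and this change produced a number 0.90 log units lower from compound 1 to compound 2 (beyond the scatter). The core of compound 3 differs from that of compound 1 by carboxy in place of chloro on an aromatic carbon, which produced a number 3.50 log units lower from compound 1 to compound 3 (beyond the scatter). Among the measured compounds shown here, compound 4 differs from compound 3 by phenyl in place of 4-(trifluoromethyl)phenoxy on an aromatic carbon, the same change, at the same place, as the one between compound 1 and compound 2.

The expectation for compound 4 rests on that earlier pair: because the change from compound 1 to compound 2 gave a number 0.90 log units lower from compound 1 to compound 2 (beyond the scatter), a step of similar size is expected here, namely a number 0.90 log units lower from compound 3 to compound 4 (beyond the scatter). The two cores differ only by the carboxy group, and nothing in the measured values suggests that this group alters how the phenyl-for-phenoxy swap plays out. Compound 4 is therefore expected to give 2.6 in this assay.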

Compound 4, partition coefficient: 2.6
The estimate for compound 4 equals the measured number at the digits printed, within the range that was stated.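

In this assay, phenyl in place of 4-(trifluoromethyl)phenoxy gave a number 0.90 log units lower from compound 3 to compound 4 (beyond the scatter) on the core carrying carboxy, a step of the same size as a number 0.90 log units lower from compound 1 to compound 2 (beyond the scatter) on the core carrying chloro. Read the other way, carboxy in place of chloro gave a number 3.50 log units lower from compound 2 to compound 4 (beyond the scatter) with phenyl present, matching a number 3.50 log units lower from compound 1 to compound 3 (beyond the scatter) with 4-(trifluoromethyl)phenoxy present, and so within these four compounds the two changes simply add up. This is a single pair of cores, which sets no rule for other cores in the series, and nothing measured here explains the match.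

From the compounds shown here alone, whether the phenyl change gives a step of this size on a core with an amine or an amide where chloro and carboxy stand remains open. Also open, going by these compounds, is how a longer chain, such as a hexyl group, would compare with phenyl and 4-(trifluoromethyl)phenoxy on either core.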